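Methoxy-to-hydroxy swap on a pyrazole urea series

A few compounds are considered here, and "the series" means these few. Any claim that something is new, unique, unknown or untested is made for them only; others in the source may bear on it.

Measured compounds:
compound 1 `COc1cc(-c2nn(-c3cccc(NC(=O)Nc4cc(C(F)(F)F)cc(C(F)(F)F)c4)c3)cc2-c2ccncc2)ccc1Cl`, 612 nM in a functional assay on A498 cells (Homo sapiens) for inhibition, read by sulforhodamine B assay, with a stated time of 48 h; on this read-out higher numbers stand for weaker inhibition of growth and lower numbers for stronger inhibition of growth
compound 2 `O=C(Nc1cccc(-n2cc(-c3ccncc3)c(-c3ccc(Cl)c(O)c3)n2)c1)Nc1cc(C(F)(F)F)cc(C(F)(F)F)c1`, 792 nM
compound 3 `COc1cc(-c2nn(-c3cccc(NC(=O)Nc4ccc(Cl)c(C(F)(F)F)c4)c3)cc2-c2ccncc2)ccc1Cl`, 837 nM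

Compound 1 and compound 2 differ by hydrogen in place of methyl on an oxygen on an aromatic ring, and in this assay that change gave a 1.3-fold higher number from compound 1 to compound 2 (0.11 log units; within the scatter). Compound 3 carries a different urea aryl part; the difference between its core and the core of compound 1 is not broken down here. Compound 4 `O=C(Nc1cccc(-n2cc(-c3ccncc3)c(-c3ccc(Cl)c(O)c3)n2)c1)Nc1ccc(Cl)c(C(F)(F)F)c1` is not yet measured. It differs from compound 3 by hydrogen in place of methyl on an oxygen on an aromatic ring, the same change as between compound 1 and compound 2, at the same place. Given the near-flat outcome seen as a 1.3-fold higher number from compound 1 to compound 2 (0.11 log units; within the scatter), the step from compound 3 to compound 4 is expected to be about as small, roughly a 1.3-fold higher number from compound 3 to compound 4 (0.10 log units; within the scatter). Compound 4 is thus estimated at 1050 nM in this assay, with a likely range from 500 nM to 2200 nM.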

Compound 4, concentration for 50% growth inhibition: 1400 nM
Compound 4: the middle estimate sits 1.3-fold (0.12 log units) below what was measured; the range from low to high includes it.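

In this assay, methoxy to hydroxy gives a 1.7-fold higher number from compound 3 to compound 4 (0.22 log units; within the scatter), and set beside the earlier step, the change carries across the two cores without a detectable difference: the same change on two cores in this assay, a 1.3-fold higher number (0.11 log units; within the scatter) from compound 1 to compound 2 and a 1.7-fold higher number (0.22 log units; within the scatter) from compound 3 to compound 4, 1.3-fold (0.11 log units) apart, within the scatter of two such steps

On these two cores, which differ in the urea aryl part, the swap therefore stays a small step. Both steps lie within the scatter, so the pair shows neither a gain nor a loss from the change, and two cores cannot show that the step would stay this small on other urea aryl parts.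

Open, going by these compounds, is what other groups at this oxygen-bearing place would do. An amine, a carboxylic acid or a longer chain such as ethoxy lies outside the compounds shown.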